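Aryl Swap on the Ring Amine Before the Next Measurement

A few compounds are considered here, and "the series" means these few. Any claim that something is new, unique, unknown or untested is made for them only; others in the source may bear on it.

compound 1 `Nc1scc(CN2CCN(c3ccc(OC(F)(F)F)cc3)CC2)c1C(=O)c1ccc(Cl)cc1`: 1%
compound 2 `Nc1scc(CN2CCN(c3ccc(F)c(F)c3)CC2)c1C(=O)c1ccc(Cl)cc1`: 1%

In an assay on CHO cells for displacement of a labelled ligand from adenosine receptor A3 (Homo sapiens), read by scintillation counting, with a stated time of 120 min, tested at 10 uM (a higher number here means more inhibition at the concentration tested (going by the name of the read-out), a lower number less inhibition), compound 1 gives 1%, and compound 2 gives 1%. Compound 2 therefore stands level with compound 1, its nearest neighbour, with no change at the digits printed from compound 1 to compound 2 (within the scatter). Compound 3 `Nc1scc(CN2CCN(c3ccccc3Cl)CC2)c1C(=O)c1ccc(Cl)cc1` differs from compound 2 by 2-chlorophenyl in place of 3,4-difluorophenyl on an amine nitrogen in a ring. Going by the values given here, the only step that bears on this change is the one from compound 1 to compound 2, and it was within the scatter. Compound 3 is thus expected to show a number 1 percentage points higher from compound 2 to compound 3 (within the scatter), no step beyond the scatter. The estimate for compound 3 is 2%, in a range from -8% to 12%.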

Compound 3, a percentage reported as inhibition, at one concentration (the size of the read-out at that concentration, not a potency): 0%
Beside the measured number, compound 3's estimate is 2 percentage points above it, and the stated range covers the measured number.
By their numbers in this assay, from the lowest: compounds 3, 1 and 2 (each within the scatter of the next).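

Set against both earlier aryl groups, 2-chlorophenyl on the amine nitrogen in the ring gives a number 1 percentage points lower from compound 2 to compound 3 (within the scatter) and a number 1 percentage points lower from compound 1 to compound 3 (within the scatter) in this assay. The series at this position now spans three differently substituted phenyl groups, including one bearing chlorine rather than fluorine, and none stands apart from the others in this read-out. Nothing measured here offers a reason for this. From the compounds shown here alone, it remains open whether a benzyl group, a pyridine ring or a plain alkyl chain on this nitrogen would separate from these phenyl groups. A change elsewhere on the shared core is equally untested by these compounds.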